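The compounds below may be only part of what the source reports. "The series", "measured", "known", "first", "only" and "open" are said of these compounds alone.

Measured so far in a functional assay on MCF7 cells (Homo sapiens) for cytotoxicity, read by MTT assay, with a stated time of 72 h (on this read-out lower numbers stand for stronger inhibition and higher numbers for weaker inhibition), for two compounds:

- compound 1 `CNC(=O)c1cc(Oc2ccc(NC(=O)c3nccc(-c4ccccc4)n3)cc2)ccn1` gives 39100 nM
- compound 2 `CNC(=O)c1cc(Oc2ccc(NC(=O)c3cc(-c4ccc(C(F)(F)F)cc4)ncn3)cc2F)ccn1` gives > 100000 nM

Among the compounds with values here, compound 1 stands at 39100 nM as the only true number in this small set. Compound 2 reads > 100000 nM here, which is a limit of the assay and not a number.

The next compound, compound 3 (`CNC(=O)c1cc(Oc2ccc(NC(=O)c3nccc(-c4cccc(Cl)c4)n3)cc2)ccn1`), alters compound 1 in one place, phenyl to 3-chlorophenyl, with chloro in place of hydrogen on an aromatic carbon. Within the data shown here, no measured pair in this assay shows what such a single change does, so any forecast is loose. The estimated 1.4-fold lower number from compound 1 to compound 3 (0.15 log units; within the scatter) is expected to be small, leaning slightly toward stronger inhibition and probably staying within the scatter. Compound 3 is therefore estimated at 28000 nM within an expected range of 11000 nM to 70000 nM on this read-out.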

Compound 3, half-maximal inhibitory concentration: > 100000 nM
Compound 3: a limit, no number (the forecaster's own chance of this, stated with the estimate: 10%); middle value at least 3.5-fold (0.55 log units) away from the limit.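

In this assay compound 3 gives > 100000 nM, which is a limit of the assay and not a number. Even so, this is the first single change that can be read in this set: chloro in place of hydrogen on this aromatic carbon gives an at least 2.5-fold higher number from compound 1 to compound 3 (0.40 log units; beyond the scatter), so the change weakens inhibition in these cells rather than leaving it unchanged. How much weaker remains unknown, because the read-out stops at a limit that now holds most of the set: the limit of > 100000 nM in this assay, at which 2 of the 3 values shown sit.

As far as these compounds go, it remains open whether this loss belongs to chloro alone or would also follow a fluorine, a methoxy group or an amine at the same place. From the compounds shown here alone, it is also open whether chloro on a different carbon of this ring would give the same result.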